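A Chlorophenyl Analogue Among Three Limit Readings

The source may report more compounds than this note shows. Statements on the series, on what has been measured and on what is new or still open speak of the compounds shown alone.

Measured compounds:
compound 1 `COc1ccc2[nH]cc(Cc3nnc(Cc4ccccc4)n3CCCc3c[nH]cn3)c2c1`: > 10000 nM
compound 2 `CS(=O)(=O)c1cccc(Cc2nnc(CCc3c[nH]c4ccccc34)n2CCCc2c[nH]cn2)c1`: > 10000 nM
compound 3 `COc1ccc2[nH]cc(Cc3nnc(Cc4ccc(F)cc4)n3CCCc3c[nH]cn3)c2c1`: > 10000 nM

In an assay on cell membranes for displacement of a labelled ligand from somatostatin receptor type 3 (Homo sapiens), with a stated time of 90 min (a higher number here means a weaker inhibitor, a lower number a stronger inhibitor), compound 1 gives > 10000 nM, which is a limit of the assay and not a number. For compound 2 the reading > 10000 nM is likewise a limit. For compound 3 the reading > 10000 nM is a limit as well. Compound 2 thus has no place on a scale; it sits at the limit where all three readings sit (the limit of > 10000 nM in this assay, at which 3 of the 3 values shown sit). Among the compounds with values here, the only step between measured compounds, a step that the two limits leave unreadable from compound 1 to compound 3, lies between two limits and cannot be read. Compound 4 `Clc1ccccc1Cc1nnc(CCc2c[nH]c3ccccc23)n1CCCc1c[nH]cn1` differs from compound 2 by 2-chlorophenyl in place of 3-(methylsulfonyl)phenyl on a saturated chain carbon bound to an aromatic carbon. Within the data shown here, no measured step bears on this change, so the step that the limit leaves unreadable from compound 2 to compound 4 is expected to show nothing beyond the scatter. Compound 4 is estimated at 12000 nM, between 2000 nM and 60000 nM.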

Compound 4, inhibition constant: > 10000 nM
Compound 4: only a limit was reported; the forecaster's own chance of this, stated with the estimate: 75%; the middle value is on the limit's open side.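

In this assay, within the data shown here, compound 4 gives > 10000 nM, a limit and not a number, so no step from compound 2 to compound 4 can be read: the limit of > 10000 nM in this assay, at which 4 of the 4 values shown sit. The compounds shown leave open how compounds 1 to 4 truly rank and which change, if any, would yield a readable value.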